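Ester chain extension and tolerated concentration in the series

The source may hold more compounds than are shown below. What is called first, only, known or untested is meant among the compounds shown, and "the series" means these compounds.

Of the compounds shown here, two have numbers so far. Compound 2 `CCCCS(=O)(=O)Oc1ccc(/C=C/C(=O)OC)cc1OC` in a toxicity assay on L02 cells (Homo sapiens) for cytotoxicity, read by MTT assay, with a stated time of 24 h (a lower number here means that less compound is tolerated, a higher number that more compound is tolerated), gives 208000 nM. Compound 1 `CCCOC(=O)/C=C/c1ccc(OS(=O)(=O)c2ccc(Cl)cc2)c(OC)c1` in this assay gives 150000 nM, a value within the scatter of compound 2, so the two numbers in hand do not separate compound 2 from compound 1. Compound 3 `CCCCS(=O)(=O)Oc1ccc(/C=C/C(=O)OCCC)cc1OC` is not yet measured; it differs from compound 2 by ethyl in place of hydrogen on a saturated chain carbon bound to an oxygen next to a carbonyl group. Among the compounds with values here, no step between measured compounds bears on this change; in this assay the step is expected to be none beyond the scatter, estimated as a 1.1-fold lower number from compound 2 to compound 3 (0.04 log units; within the scatter). Compound 3 is expected to give 190000 nM in this assay, within 95000 nM to 380000 nM.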

Compound 3, half-maximal cytotoxic concentration: 61800 nM
Estimate against measurement, compound 3: 3.1-fold (0.49 log units) above, outside the stated range (below it).
By their numbers in this assay, from the lowest: compound 3; then compounds 1 and 2 (each within the scatter of the next).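

In this assay, methoxycarbonyl to propoxycarbonyl gives a 3.4-fold lower number from compound 2 to compound 3 (0.53 log units; beyond the scatter), so the ester chain matters at this position when butyl sits on the sulfonyl sulfur. With propoxycarbonyl held constant, the sulfonyl substituent also registers: butyl in place of 4-chlorophenyl gives a 2.4-fold lower number from compound 1 to compound 3 (0.39 log units; beyond the scatter). No available data account for either step.

Open, going by these compounds, is whether a longer chain, such as a hexyl ester, would lower the number further, or a carboxylic acid at this position would reverse the step. Also open, on these data alone, is whether the ester step carries over to the 4-chlorophenyl sulfonyl compounds.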